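The source may hold more compounds than are shown below. What is called first, only, known or untested is meant among the compounds shown, and "the series" means these compounds.

The measured compounds and their values:

Compound 1, `O=C(Nc1ccc(C(F)(F)F)cc1)c1cc(Cl)ccc1O`, gives 510 nM in a functional assay on HL-60 cells (Homo sapiens) for cytotoxicity, read by luminescence and CellTiter-Glo, with a stated time of 3 days; on this read-out higher numbers stand for weaker inhibition and lower numbers for stronger inhibition.
Compound 2, `O=C(Nc1ccc(OC(F)(F)F)c(Cl)c1)c1cc(F)ccc1O`, gives 550 nM in this assay.
Compound 3, `O=C(Nc1ccc(C(F)(F)F)cc1)c1cc(F)ccc1O`, gives 490 nM in this assay.

All three values lie within the usual scatter of one another, so none of them can be told apart on this read-out. Compound 1 and compound 3 share a core and differ in a single place, (chloro in place of fluoro on an aromatic carbon). The step this change made in this assay is a 1.0-fold higher number from compound 3 to compound 1 (0.02 log units; within the scatter), which is within the scatter. Compound 2 carries a different core from compound 3; the difference between the two cores is not broken down here.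

Compound 4, `O=C(Nc1ccc(OC(F)(F)F)c(Cl)c1)c1cc(Cl)ccc1O`, has not yet been measured. It is derived from compound 2 by chloro in place of fluoro on an aromatic carbon. The place of this change is described in the same words as the change from compound 3 to compound 1, so it is the same change, made on the core of compound 2 instead. Among the compounds with values here, the only guide to its size is that single earlier step, and because that step was a 1.0-fold higher number from compound 3 to compound 1 (0.02 log units; within the scatter), the step expected in this assay is a 1.0-fold higher number from compound 2 to compound 4 (0.01 log units; within the scatter). Compound 4 is therefore expected to give about 560 nM in this assay, with a likely range from 280 nM to 1100 nM. This estimate rests on one precedent only and is uncertain to that extent.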

Compound 4, half-maximal inhibitory concentration: 450 nM
Compound 4: middle estimate off by 1.2-fold (0.09 log units), on the high side; measured number inside the range.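

On the core of compound 2, chloro in place of fluoro gives a 1.2-fold lower number from compound 2 to compound 4 (0.09 log units; within the scatter) in this assay. Set beside the same change on the other core, the two steps cannot be told apart: the same change on two cores in this assay, a 1.0-fold higher number (0.02 log units; within the scatter) from compound 3 to compound 1 and a 1.2-fold lower number (0.09 log units; within the scatter) from compound 2 to compound 4, 1.3-fold (0.10 log units) apart, within the scatter of two such steps. Within the data shown here, in these two pairs, then, the exchange of fluoro for chloro leaves the number within the scatter on both cores, but this is a carry-over of "no visible step" only: it does not show that a step of real size would transfer from one core to the other, and two pairs cannot show how the change would behave on any further core.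

Among the compounds shown, this place on the ring holds only fluoro or chloro, so it remains open whether a different group there, such as a nitrile, a methoxy group or an amine, would give a step beyond the scatter. As far as these compounds go, it also remains open how the number would respond if the hydroxy group gave way to another group, such as a carboxylic acid, or if the amide link between the two rings were altered.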